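Pyrrolidinone variation on a fused bicyclic core: solubility notes

The compounds below may be only part of what the source reports. "The series", "measured", "known", "first", "only" and "open" are said of these compounds alone.

Measured so far:
- compound 1, `Cn1nccc1-c1cnc(NCc2c(F)ccc3c2CCO3)c2cn[nH]c(=O)c12`: 2000 nM
- compound 2, `CC1(C)CC(=O)N(c2cnc(NCc3c(F)ccc4c3CCO4)n3cnnc23)C1`: 57000 nM
- compound 3, `O=C1CC2(CC2)CN1c1cnc(NCc2c(F)ccc3c2CCO3)n2cnnc12`: 130000 nM

In a physicochemical assay for solubility, read by LC-MS, in phosphate buffer, with a stated time of 24 h, at pH 7.4 (on this read-out higher numbers stand for higher solubility and lower numbers for lower solubility), compound 3 gives the highest number of the three. Its nearest neighbour is compound 2, at 57000 nM in this assay, and the furthest is compound 1, at 2000 nM in this assay. Going by the values given here, the only step among the measured compounds that touches the same position is a 2.3-fold higher number from compound 2 to compound 3 (0.36 log units; beyond the scatter), a modest gain obtained by exchanging one eight-atom group for another.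

Compound 4, `C[C@H]1CC(=O)N(c2cnc(NCc3c(F)ccc4c3CCO4)n3cnnc23)C1`, continues at that position: a group of 7 heavy atoms (5 carbon, 1 nitrogen, 1 oxygen; one five-membered non-aromatic ring with 1 hetero atom) in place of a group of 8 heavy atoms (6 carbon, 1 nitrogen, 1 oxygen; one three-membered non-aromatic ring of carbon only, one five-membered non-aromatic ring with 1 hetero atom), on an aromatic carbon. Among the compounds with values here, the group entering is smaller by one carbon and carries a defined stereocentre; no measured pair shows this particular exchange, so the expectation rests on compound 2 and compound 3 alone, whose two values bracket a fairly narrow band at the top of the series. With a group no larger than either of those, compound 4 is expected to stay in that band, and the step of a 1.2-fold higher number from compound 3 to compound 4 (0.06 log units; within the scatter) is expected to lie within the usual scatter, with a slight lean upward. Compound 4 is therefore estimated at 150000 nM in this assay, with a range from 60000 nM to 400000 nM.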

Compound 4, solubility: 200000 nM
Compound 4: middle estimate off by 1.3-fold (0.12 log units), on the low side; low and high end bracket the measured number.
By their numbers in this assay, from the lowest: compound 1; then compound 2; then compounds 3 and 4 (each within the scatter of the next).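

In this assay, going by these compounds alone, 4-methyl-2-oxopyrrolidin-1-yl in place of 4,4-dimethyl-2-oxopyrrolidin-1-yl gives a 3.5-fold higher number from compound 2 to compound 4 (0.55 log units; beyond the scatter), the first step at this aromatic carbon between two simply methyl-substituted groups, and it shows that the count of methyl groups on the ring can be read in this assay. The exchange of the group with the three-membered ring for 4-methyl-2-oxopyrrolidin-1-yl gives a 1.5-fold higher number from compound 3 to compound 4 (0.19 log units; within the scatter), so these two groups cannot be told apart here despite the different heavy-atom counts and the defined stereocentre, and of the three groups on this core only the 4,4-dimethyl group of compound 2 stands apart. No accompanying measurement offers an explanation for either step.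

On these data alone, it remains open whether the opposite stereoisomer of the 4-methyl group, or the unsubstituted 2-oxopyrrolidin-1-yl group, would read with compound 3 and compound 4 or with compound 2. Also open, as far as these compounds go, is what an amine or a carboxylic acid on the pyrrolidinone ring would do to the read-out, and whether the same exchanges would behave alike on the core of compound 1.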